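The source may report more compounds than this note shows. Statements on the series, on what has been measured and on what is new or still open speak of the compounds shown alone.

Measured compounds in a functional assay on HepG2 cells (Homo sapiens) for cytotoxicity, with a stated time of 24 h; on this read-out lower numbers stand for stronger inhibition and higher numbers for weaker inhibition:
- compound 1 `O=C(N/N=C/c1cc(I)cc(I)c1O)c1ccc(O)cc1` gives 19200 nM
- compound 2 `O=C(N/N=C/c1cc(I)cc(I)c1O)c1ccc(C(F)(F)F)cc1` gives 11700 nM
- compound 3 `O=C(N/N=C/c1cc(I)c(O)c(I)c1)c1ccc(O)cc1` gives 110000 nM

Compound 3 stands highest of these three numbers in this assay. Its nearest neighbour is compound 1, which gives a number lower by a margin beyond the scatter, and compound 2 lies further still, also beyond the scatter. Compound 4 `O=C(N/N=C/c1cc(I)c(O)c(I)c1)c1ccc(C(F)(F)F)cc1` is not yet measured; it differs from compound 3 by trifluoromethyl in place of hydroxy on an aromatic carbon, the group entering on a six-membered aromatic ring of carbon only, para to a large group.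

For the measured compounds named here, one measured step bears directly on this change: the same exchange on the core of compound 1, where a 1.6-fold lower number from compound 1 to compound 2 (0.22 log units; within the scatter). That step stayed within the scatter, so for compound 4 no shift beyond the scatter is expected in this assay, with at most a small drift towards a lower number. The estimate for compound 4 in this assay is therefore 70000 nM, within 25000 nM to 200000 nM, which means an expected step of a 1.6-fold lower number from compound 3 to compound 4 (0.20 log units; within the scatter).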

Compound 4, half-maximal inhibitory concentration: 57400 nM
For compound 4 the middle estimate is 1.2-fold (0.09 log units) above the measured one, within the range that was stated.
By their numbers in this assay, from the lowest: compounds 2 and 1 (each within the scatter of the next); then compounds 4 and 3 (each within the scatter of the next).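

In this assay, the exchange of hydroxy for trifluoromethyl now has a second reading on a different core, with a 1.9-fold lower number from compound 3 to compound 4 (0.28 log units; within the scatter). The earlier compounds shown here showed this change on the core of compound 1 alone, whereas it now also stays within the scatter on the core of compound 3, so at this position on the aromatic ring the two groups give no separable difference on either core. The two readings also agree closely with each other: the same change on two cores in this assay, a 1.6-fold lower number (0.22 log units; within the scatter) from compound 1 to compound 2 and a 1.9-fold lower number (0.28 log units; within the scatter) from compound 3 to compound 4, 1.2-fold (0.07 log units) apart, within the scatter of two such steps

The compounds shown leave open whether another group at this position, such as an amine, a carboxylic acid or a methoxy group, would shift the number beyond the scatter on either core. For the compounds shown here, they also show this change on only two cores, so its size on any other core remains unknown.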